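Phenyl to Pyrazolyl on the Sulfonyl: Expected Clearance

The compounds below may be only part of what the source reports. "The series", "measured", "known", "first", "only" and "open" are said of these compounds alone.

Of the compounds shown here, three have so far been measured in an ADME assay (liver) for metabolic stability, with Liver microsome (Homo sapiens) as the target, read by LC-MS, using microsomes and NADPH, with a stated time of 5 min, at 37 degrees C; on this read-out lower numbers stand for slow clearance and higher numbers for fast clearance. Compound 1 `CCn1c([C@@H](C)NS(=O)(=O)c2ccc(Cl)cc2)nc2cccc(Cl)c21` returns only a limit of the assay, > 100 mL.min-1.g-1, and not a number. Compound 2 `CCn1c(C(C)NS(=O)(=O)c2ccc(Cl)cc2)nc2ncccc21` gives 15 mL.min-1.g-1 in this assay. Compound 3 `CCn1c([C@@H](C)NS(=O)(=O)c2ccccc2)nc2ccc(C(F)(F)F)cc21` gives 14 mL.min-1.g-1 in this assay. Going by the values given here, of the two values that are numbers, the one for compound 3 is the smaller, but the value for compound 2 lies within the usual scatter of it, so the two cannot be told apart. The remaining entry is the limit of > 100 mL.min-1.g-1 in this assay, at which 1 of the 3 values shown sits, which belongs to compound 1 alone.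

Compound 4 `CCn1cc(S(=O)(=O)N[C@H](C)c2nc3ccc(C(F)(F)F)cc3n2CC)cn1` has not yet been measured in this assay. It differs from compound 3 in a single place: 1-ethyl-1H-pyrazol-4-yl in place of phenyl on a sulfonyl sulfur. Among the compounds with values here, no measured pair in this set shares that change, so there is no direct precedent for what it does to clearance. In the absence of such a pair, the step from compound 3 to compound 4 is expected to be small, in no particular direction, and is estimated as no change at the digits printed from compound 3 to compound 4 (within the scatter). Compound 4 is accordingly estimated at 14 mL.min-1.g-1 in this assay, with a plausible span from 5 mL.min-1.g-1 to 40 mL.min-1.g-1.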

Compound 4, intrinsic clearance in microsomes: 95 mL.min-1.g-1
Compound 4: middle estimate off by 6.8-fold (0.83 log units), on the low side; the measured number lies above the stated range.
By their numbers in this assay, from the lowest: compounds 3 and 2 (each within the scatter of the next); then compound 4. At a limit, above all of these: compound 1.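

In this assay, the sulfonyl sulfur proves to be a place where the choice of group shows clearly in the read-out: with everything else held the same, 1-ethyl-1H-pyrazol-4-yl in place of phenyl gives a 6.8-fold higher number from compound 3 to compound 4 (0.83 log units; beyond the scatter) and lies beyond the usual scatter. The earlier compounds shown here could not show this, as compounds 1, 2 and 3 differ from one another in more than one place and offered no step that isolated a single group on the sulfonyl sulfur. Nothing measured in this set bears on why the step has this size or direction.

On these data alone, what remains open is whether the higher number belongs to the five-membered aromatic ring itself or to the ethyl group it carries, a question that a methyl group in place of that ethyl, or a pyridine ring in place of the whole 1-ethyl-1H-pyrazol-4-yl, would help to separate. Also open, as far as these compounds go, is whether the same exchange on the sulfonyl sulfur would bring a step of similar size on the cores of compound 1 and compound 2, neither of which has a partner here that differs only at this place.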